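The source may report more compounds than this note shows. Statements on the series, on what has been measured and on what is new or still open speak of the compounds shown alone.

In a functional assay on A549 cells (Homo sapiens) for antiproliferative activity, read by MTT assay, with a stated time of 48 h (on this read-out lower numbers stand for stronger inhibition and higher numbers for weaker inhibition), compound 1 (`COC/C1=C/C[C@](C)(CCC=C(C)C)/C=C/[C@@H](OC(=O)C=C(C)C)[C@](C)(OC)/C=C/C1=O`) gives 4180 nM and compound 2 (`CC(=O)O[C@]1(C)/C=C/C(=O)/C(CO)=C\C[C@](C)(CCC=C(C)C)/C=C/[C@H]1OC(=O)C=C(C)C`) gives 3150 nM as its value. Compound 2 therefore stands level with compound 1, since these two values lie within the usual scatter of each other. Compound 3 (`CO[C@]1(C)/C=C/C(=O)/C(CO)=C\C[C@](C)(CCC=C(C)C)/C=C/[C@H]1OC(=O)C=C(C)C`) has not yet been measured. It matches compound 2 except for one change, methyl in place of acetyl on an oxygen on a saturated carbon, which turns an acetoxy into a methoxy. Going by the values given here, no measured pair shows this change on its own, so the data give no direct size for it. Among the compounds with values here, with only two close values to go on, no shift beyond the scatter is expected in this assay and no firm direction can be named. The expected step is small: a 1.1-fold higher number from compound 2 to compound 3 (0.05 log units; within the scatter) by this estimate. For compound 3 the estimated value is 3500 nM with an expected range from 1500 nM to 8000 nM in the same read-out.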

Compound 3, half-maximal inhibitory concentration: 14400 nM
Beside the measured number, compound 3's estimate is 4.1-fold (0.61 log units) below it; the measured number lies above the stated range.
By their numbers in this assay, from the lowest: compounds 2 and 1 (each within the scatter of the next); then compound 3.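

In this assay, methyl in place of acetyl on an oxygen on a saturated carbon, which turns acetoxy into methoxy, proves to be far from a neutral swap, giving a 4.6-fold higher number from compound 2 to compound 3 (0.66 log units; beyond the scatter). A second single change also ends at compound 3, hydrogen in place of methyl on an oxygen on a saturated carbon, giving a 3.4-fold higher number from compound 1 to compound 3 (0.54 log units; beyond the scatter), so two separate steps now have a size, which the earlier two compounds could not supply because they differ in more than one place. Nothing measured here explains either step.

Still open, as far as these compounds go, is whether a longer ester such as butanoyl on the first oxygen would give a lower number than acetyl. A free hydroxyl at that oxygen, or an amine in its place, also remains untested among the compounds shown.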